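Replacing a methoxyphenyl with a trifluoromethylphenyl on the triazole nitrogen

The source may hold more compounds than are shown below. What is called first, only, known or untested is meant among the compounds shown, and "the series" means these compounds.

Of the compounds shown here, three sharing one core have been tested in a functional assay on PC-12 cells (Rattus norvegicus) for cytotoxicity, read by MTT assay, with stated times of 2 h and 24 h, tested at 5 uM; a higher number here means a stronger effect of the compound at the concentration tested, a lower number a weaker effect. Compound 1 `Oc1cc(C(F)(F)F)ccc1-c1nc(-c2ccccc2O)n(-c2ccc(I)cc2)n1` gives 94.4%. Compound 2 `Oc1cc(C(F)(F)F)ccc1-c1nc(-c2ccccc2O)n(-c2ccc(C(F)(F)F)cc2)n1`, which carries trifluoromethyl in place of iodo on an aromatic carbon, gives 90.5%; the step of a number 3.9 percentage points lower from compound 1 to compound 2 (within the scatter). Compound 3 `COc1ccccc1-n1nc(-c2ccc(C(F)(F)F)cc2O)nc1-c1ccccc1O` gives 85.6%. On paper this is the smallest of the three numbers, but the steps of a number 8.8 percentage points lower from compound 1 to compound 3 (within the scatter) and a number 4.9 percentage points lower from compound 2 to compound 3 (within the scatter) both lie within the scatter, so the three compounds cannot really be told apart in this assay.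

Compound 4 `Oc1cc(C(F)(F)F)ccc1-c1nc(-c2ccccc2O)n(-c2cccc(C(F)(F)F)c2)n1` is not yet measured. It differs from compound 3 in one place: 3-(trifluoromethyl)phenyl in place of 2-methoxyphenyl on an aromatic nitrogen. Going by the values given here, the steps that bear on this change are a number 8.8 percentage points lower from compound 1 to compound 3 (within the scatter) and a number 4.9 percentage points lower from compound 2 to compound 3 (within the scatter), since each of them swaps the group on the same aromatic nitrogen, and both were within the scatter. Going back from 2-methoxyphenyl to a phenyl bearing trifluoromethyl is therefore expected to give a step of a number 4.4 percentage points higher from compound 3 to compound 4 (within the scatter), no change beyond the scatter. Compound 4 is estimated to give 90%, with a range from 80% to 97%.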

Compound 4, a percentage reported as activity, at one concentration (the size of the read-out at that concentration, not a potency): 92.2%
Estimate against measurement, compound 4: 2.2 percentage points below, and the stated range covers the measured number.
By their numbers in this assay, from the lowest: compounds 3, 2, 4 and 1 (each within the scatter of the next).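

In this assay, the trifluoromethyl-bearing phenyl groups cannot be told apart: exchanging 4-(trifluoromethyl)phenyl for 3-(trifluoromethyl)phenyl on the aromatic nitrogen gives a step that is a number 1.7 percentage points higher from compound 2 to compound 4 (within the scatter). The comparisons with the two other groups at this nitrogen also stay inside the usual variation, with steps that are a number 6.6 percentage points higher from compound 3 to compound 4 (within the scatter) and a number 2.2 percentage points lower from compound 1 to compound 4 (within the scatter), so 2-methoxyphenyl, 4-iodophenyl and both trifluoromethylphenyl groups all read alike at this one concentration. No independent measurement is available to explain this similarity.

Every group shown on this nitrogen is a substituted phenyl ring, so it remains open whether a phenyl ring carrying an amine or a carboxylic acid would read differently. Going by these compounds, a longer alkyl chain in place of the ring is equally open.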